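A few compounds are considered here, and "the series" means these few. Any claim that something is new, unique, unknown or untested is made for them only; others in the source may bear on it.

Of the compounds shown here, two on a shared core have been measured in an assay on CHO cells for displacement of a labelled ligand from adenosine receptor A3 (Homo sapiens), read by scintillation counting, with a stated time of 60 min; a lower number here means a stronger inhibitor, a higher number a weaker inhibitor. Compound 1 `CNC(=O)[C@@]12C[C@@H]1[C@@H](n1cnc3c(NC)nc(C#Cc4ccc(OC)cc4)nc31)[C@H](O)[C@@H]2O` carries a 4-methoxyphenyl on a triple-bonded carbon, and in this assay compound 1 gives 0.63 nM. Compound 2 `CNC(=O)[C@@]12C[C@@H]1[C@@H](n1cnc3c(NC)nc(C#Cc4ncccn4)nc31)[C@H](O)[C@@H]2O` carries a pyrimidin-2-yl in that place, and in this assay compound 2 gives 1.97 nM. Within the data shown here, the one step measured so far, a 3.1-fold higher number from compound 1 to compound 2 (0.50 log units; beyond the scatter), shows that exchanging the aromatic group on the triple-bonded carbon shifts the number only modestly. Of the two values shown, compound 2 has the higher one, meaning the weaker inhibition.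

Compound 3 `CNC(=O)[C@@]12C[C@@H]1[C@@H](n1cnc3c(NC)nc(C#Cc4cccnn4)nc31)[C@H](O)[C@@H]2O` is the next compound, not yet measured. The change is pyridazin-3-yl in place of pyrimidin-2-yl on a triple-bonded carbon. The two groups consist of the same atoms joined differently, so the exchange is of a gentler kind than the one already seen. Among the measured compounds shown here, only that single modest step bears on it, so a step of similar or smaller size in this assay is expected, in either direction, quite possibly within the scatter. The expected step is a 1.3-fold higher number from compound 2 to compound 3 (0.10 log units; within the scatter). For compound 3 the estimate in this assay is 2.5 nM, with a range from 0.9 nM to 7 nM.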

Compound 3, inhibition constant: 3.53 nM
Compound 3: the middle estimate sits 1.4-fold (0.15 log units) below what was measured, within the range that was stated.
By their numbers in this assay, from the lowest: compound 1; then compounds 2 and 3 (each within the scatter of the next).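

In this assay the exchange of pyrimidin-2-yl for pyridazin-3-yl on a triple-bonded carbon gives a 1.8-fold higher number from compound 2 to compound 3 (0.25 log units; within the scatter) and so leaves no readable difference, even though the two rings are built from the same atoms joined differently. At this position, then, the way the atoms of this ring are joined has no effect that these data can separate from ordinary repeat variation, at least for this one pair. The exchange of 4-methoxyphenyl for pyridazin-3-yl gives a 5.6-fold higher number from compound 1 to compound 3 (0.75 log units; beyond the scatter) and, together with the earlier step from compound 1 to compound 2, leaves compound 1 the strongest inhibitor of the three, but nothing shown explains that gap.

The three compounds leave open which part of 4-methoxyphenyl matters, the methoxy group or the carbon-only ring, and an unsubstituted phenyl would be the direct comparison. They also leave open how far this position tolerates quite different groups, such as an amine, a carboxylic acid or a longer chain in place of the aromatic ring.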